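This account rests on a few compounds, and the source may have more. Where it says the series, first, only, none or still open, it means among the compounds named here.

Working notes on the series, values in a functional assay on MCF7 cells (Homo sapiens) for antiproliferative activity, read by sulforhodamine B assay, with a stated time of 48 h; a lower number here means a stronger inhibitor, a higher number a weaker inhibitor:

compound 1 `O=C1NCCN1c1ccc(S(=O)(=O)Nc2ccc(F)cc2)cc1`: 690 nM
compound 2 `CCc1ccc(NS(=O)(=O)c2ccc(N3CCNC3=O)cc2)cc1`: 810 nM
compound 3 `O=C1NCCN1c1ccc(S(=O)(=O)Nc2ccc(Cl)cc2)cc1`: 170 nM

Compound 3 has the lowest of the three numbers, and it is separated from both others beyond the scatter: a 4.1-fold lower number from compound 1 to compound 3 (0.61 log units; beyond the scatter) and a 4.8-fold lower number from compound 2 to compound 3 (0.68 log units; beyond the scatter). Compound 4 `COc1ccccc1NS(=O)(=O)c1ccc(N2CCNC2=O)cc1` is the next case, with 2-methoxyphenyl in place of 4-chlorophenyl on a sulfonamide nitrogen.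

The three measured steps all exchange a group on the aromatic ring, and none of them involves methoxy, so they bear on this change only indirectly. Removing chloro gave modest steps to higher numbers in both measured cases, while a 1.2-fold higher number from compound 1 to compound 2 (0.07 log units; within the scatter) stayed within the scatter. Among the compounds with values here, a step of similar or slightly larger size towards a higher number is therefore expected in this assay, though this rests on only three compounds.

The estimated step is a 5.3-fold higher number from compound 3 to compound 4 (0.72 log units; beyond the scatter). For compound 4 the expected value is 900 nM, with an estimated range of 300 nM to 3000 nM.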

Compound 4, half-maximal inhibitory concentration: 770 nM
Compound 4: the middle estimate sits 1.2-fold (0.07 log units) above what was measured; the measured number falls inside the stated range.
By their numbers in this assay, from the lowest: compound 3; then compounds 1, 4 and 2 (each within the scatter of the next).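

In this assay, 2-methoxyphenyl on the sulfonamide nitrogen does not keep the standing of 4-chlorophenyl, a 4.5-fold higher number from compound 3 to compound 4 (0.66 log units; beyond the scatter), so compound 3 now stands apart from three other compounds rather than two. Compound 4 cannot be told apart from the 4-ethylphenyl and 4-fluorophenyl compounds, a 1.1-fold lower number from compound 2 to compound 4 (0.02 log units; within the scatter) and a 1.1-fold higher number from compound 1 to compound 4 (0.05 log units; within the scatter), so a group carrying a hydrogen-bond acceptor, where 4-chlorophenyl has none, falls in the same band as those two. Nothing at hand explains why 4-chlorophenyl alone stands apart.

The compounds shown do not separate the identity of the group from its place on the ring; 2-chlorophenyl and 4-methoxyphenyl would address that. On these data alone, how an amine or a carboxylic acid on the same ring would read remains open.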